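Halogen exchange on the pendant aryl of compound 1

The source may hold more compounds than are shown below. What is called first, only, known or untested is meant among the compounds shown, and "the series" means these compounds.

Measured compounds, read in a functional assay on PC-3 cells (Homo sapiens) for antiproliferative activity, read by MTT assay, tested at 1 uM; a lower number here means a weaker effect, a higher number a stronger effect of the compound at the concentration tested:
compound 1 `COc1cc(C2=NN(C(C)=O)C(c3cc(Cl)cc(Cl)c3)O2)cc(OC)c1OC` gives 52.7%
compound 2 `COc1cc(C(=O)N/N=C/c2ccccc2C(F)(F)F)cc(OC)c1OC` gives 45%
compound 3 `COc1cc(C(=O)N/N=C/c2ccccc2F)cc(OC)c1OC` gives 70.6%

Compound 1 stands second highest of the three numbers in this assay. Its nearest neighbour is compound 2, whose value lies within the scatter of that of compound 1, so no order between these two can be stated. Compound 3 lies beyond the scatter above compound 1.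

The step under consideration leads from compound 1 to compound 4 `COc1cc(C2=NN(C(C)=O)C(c3ccc(F)c(F)c3)O2)cc(OC)c1OC`. The change is 3,4-difluorophenyl in place of 3,5-dichlorophenyl on a saturated ring carbon.

Among the compounds with values here, only one measured step exists in this set: a number 25.6 percentage points higher from compound 2 to compound 3 (beyond the scatter). It exchanges one halogen-bearing group for another on an aromatic carbon, but it sits on a different core from that of compound 1 and concerns a single substituent. Within the data shown here, it bears on the present step only loosely, and no measured step shows what two fluorines in place of two chlorines do on the core of compound 1. The expected step is therefore a number 0.7 percentage points lower from compound 1 to compound 4 (within the scatter), which is none beyond the scatter in either direction. The estimated value for compound 4 in this assay is 52%, with a range from 32% to 72%.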

Compound 4, a percentage reported as inhibition, at one concentration (the size of the read-out at that concentration, not a potency): 35.5%
For compound 4 the middle estimate is 16.5 percentage points above the measured one, within the range that was stated.
By their numbers in this assay, from the lowest: compounds 4, 2 and 1 (each within the scatter of the next, the first and the last beyond it); then compound 3.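

In this assay, within the data shown here, the aryl group on the saturated ring carbon of the core of compound 1 proves sensitive to exchange, with 3,4-difluorophenyl in place of 3,5-dichlorophenyl giving the first measured step on this core (a number 17.2 percentage points lower from compound 1 to compound 4 (beyond the scatter)). The exchange alters both the halogen and where it stands on the aryl ring, so the step belongs to the pair of groups as a whole and not to either alteration alone, and the upward step on another core with a single substituent (a number 25.6 percentage points higher from compound 2 to compound 3 (beyond the scatter)) does not carry over to it. Nothing available on these compounds accounts for the size or direction of the step on the core of compound 1.

The compounds shown contain no pair that changes the halogen while keeping its placement, or the reverse, so which of the two alterations matters remains open. As far as these compounds go, it is also open how this position responds to a group without halogen, such as a plain phenyl or an aminophenyl, and whether the acetyl group on the shared core can be exchanged for a longer acyl chain.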